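The compounds below may be only part of what the source reports. "The series", "measured", "known", "first", "only" and "open" are said of these compounds alone.

In an ADME assay on MRC5 cells (Homo sapiens) for inhibition, with a stated time of 72 h (a lower number here means that less compound is needed, a higher number that more compound is needed for the effect), compound 3 `COc1cccc(OC)c1C(=O)Nc1c[nH]nc1C(=O)NCCCN(C)C` has no exact number, only a limit of > 50000 nM. Compound 1 `COc1cccc(OC)c1C(=O)Nc1c[nH]nc1C(=O)NC1CC1` also gives only a limit, > 50000 nM. Compound 2 `COc1cccc(OC)c1C(=O)Nc1c[nH]nc1C(=O)N[C@H]1CC[C@H](O)CC1` gives 34000 nM. The series thus sits largely at the limit of > 50000 nM in this assay, at which 2 of the 3 values shown sit. Compound 4 `COC(=O)c1n[nH]cc1NC(=O)c1c(OC)cccc1OC` carries methoxy in place of (3-(dimethylamino)propyl)amino on a carbonyl carbon. For the measured compounds named here, no measured step makes this exact change, and the nearest ones only swap the group on the amide-type nitrogen. They are an at least 1.4-fold lower number from compound 1 to compound 2 (0.16 log units; that floor lies within the scatter), an at least 1.4-fold higher number from compound 2 to compound 3 (0.16 log units; that floor lies within the scatter) and a step that the two limits leave unreadable from compound 1 to compound 3. None of them shows a readable step beyond the scatter, so none is expected here either. The expected step is a number no higher from compound 3 to compound 4 (the limit leaves the size open). For compound 4 the estimated value is 50000 nM, with an expected range from 25000 nM to 80000 nM.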

Compound 4, half-maximal effective concentration: > 50000 nM
Compound 4: a limit, no number; the forecaster's own chance of this, stated with the estimate: 75%; the middle value sits exactly at the limit.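

Earlier changes only swapped the group on the amide-type nitrogen, whereas compound 4 has methoxy in place of that whole amino group on the carbonyl carbon, and in this assay compound 4 gives only a limit, > 50000 nM. For the compounds shown here, the one readable comparison is an at least 1.4-fold higher number from compound 2 to compound 4 (0.16 log units; that floor lies within the scatter), while the steps to compound 1 and compound 3 cannot be read, as both ends are limits. The series now gathers at one point: the limit of > 50000 nM in this assay, at which 3 of the 4 values shown sit.

Going by these compounds, whether a carboxylic acid on this carbonyl carbon would give an exact number remains open. So does how far past their limits compound 1, compound 3 and compound 4 lie.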